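This account rests on a few compounds, and the source may have more. Where it says the series, first, only, none or still open, it means among the compounds named here.

In an ADME assay on HEK-293T cells (Homo sapiens) for cytotoxicity, read by MTT assay, with a stated time of 24 h (a higher number here means that more compound is tolerated, a lower number that less compound is tolerated), compound 1 `FC(F)(F)c1ccc(-c2nn(-c3ccccc3)cc2-c2nc3ccccc3[nH]2)cc1` gives 167000 nM and compound 2 `O=[N+]([O-])c1ccc(S(=O)(=O)n2c(-c3cn(-c4ccccc4)nc3-c3ccc(C(F)(F)F)cc3)nc3ccccc32)cc1` gives 163000 nM, so the two stand level within the usual scatter. Compound 3 `O=S(=O)(c1ccc(F)cc1)n1c(-c2cn(-c3ccccc3)nc2-c2ccc(C(F)(F)F)cc2)nc2ccccc21` has fluoro in place of nitro on an aromatic carbon, para to a large group: fluoro in place of nitro on an aromatic carbon. Among the compounds with values here, the one measured step that bears on this change is a 1.0-fold lower number from compound 1 to compound 2 (0.01 log units; within the scatter), which came from (4-nitrophenyl)sulfonyl in place of hydrogen on an aromatic nitrogen. On that evidence, no step beyond the scatter is expected in this assay, and the estimated step is a 1.0-fold lower number from compound 2 to compound 3 (0.01 log units; within the scatter). For compound 3 the expected value is 160000 nM, with an estimated range of 85000 nM to 300000 nM.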

Compound 3, half-maximal cytotoxic concentration: 157000 nM
Beside the measured number, compound 3's estimate is 1.0-fold (0.01 log units) above it; the range from low to high includes it.
By their numbers in this assay, from the lowest: compounds 3, 2 and 1 (each within the scatter of the next).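

The earlier compounds shown here showed only that adding the (4-nitrophenyl)sulfonyl group left the number level in this assay, so the nitro group itself might have mattered. Here, fluoro in place of nitro on the aromatic carbon gives no step beyond the scatter (a 1.0-fold lower number from compound 2 to compound 3 (0.02 log units; within the scatter)), and (4-fluorophenyl)sulfonyl in place of hydrogen on the aromatic nitrogen also stays within it (a 1.1-fold lower number from compound 1 to compound 3 (0.03 log units; within the scatter)). No measurement is available that would explain this lack of change. Whether an amine or a carboxylic acid at this place would shift the number remains open, since nitro and fluoro are the only two groups shown there.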